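This account rests on a few compounds, and the source may have more. Where it says the series, first, only, none or still open, it means among the compounds named here.

Three compounds share one core and differ in how two chlorine atoms sit on a phenyl ring at the end of the chain. In a functional assay on PC-3 cells (Homo sapiens) for inhibition, read by MTT assay, with a stated time of 72 h (a higher number here means a weaker inhibitor, a lower number a stronger inhibitor), compound 1 `O=C(/C=C/c1ccccc1Oc1ncnc2ccc(Cl)cc12)/C=C/c1cccc(Cl)c1Cl` gives 8350 nM, compound 3 `O=C(/C=C/c1ccccc1Oc1ncnc2ccc(Cl)cc12)/C=C/c1c(Cl)cccc1Cl` gives 7980 nM, and compound 2 `O=C(/C=C/c1ccc(Oc2ncnc3ccc(Cl)cc23)cc1)/C=C/c1c(Cl)cccc1Cl` gives 9300 nM, the highest of the three numbers, though its gaps to compound 1 and compound 3 both lie within the scatter. The change to compound 4 `O=C(/C=C/c1ccc(Oc2ncnc3ccc(Cl)cc23)cc1)/C=C/c1ccc(Cl)c(Cl)c1` is 3,4-dichlorophenyl in place of 2,6-dichlorophenyl on a double-bonded chain carbon bound to a double-bonded chain carbon. For the measured compounds named here, the one comparable step, a 1.0-fold lower number from compound 1 to compound 3 (0.02 log units; within the scatter), also moved the two chlorine atoms on that ring and stayed within the scatter, so no step beyond the scatter is expected here. Compound 4 is therefore estimated at 9000 nM, between 4500 nM and 18000 nM, an expected 1.0-fold lower number from compound 2 to compound 4 (0.01 log units; within the scatter).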

Compound 4, half-maximal inhibitory concentration: 18800 nM
For compound 4 the middle estimate is 2.1-fold (0.32 log units) below the measured one, and the stated range ends below it.
By their numbers in this assay, from the lowest: compounds 3, 1 and 2 (each within the scatter of the next); then compound 4.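

For the compounds shown here, with 3,4-dichlorophenyl in place of 2,6-dichlorophenyl, the result is a 2.0-fold higher number from compound 2 to compound 4 (0.31 log units; beyond the scatter) and so a weaker inhibitor, the first step here beyond the scatter. The earlier step from 2,3-dichlorophenyl to 2,6-dichlorophenyl, a 1.0-fold lower number from compound 1 to compound 3 (0.02 log units; within the scatter), showed no such difference, so the placing of the two chlorine atoms can matter on this ring, at least in this pair. Nothing measured here explains the change. Still open, on these data alone, is whether 3,4-dichlorophenyl would act the same way on the core of compound 1, and how a ring carrying an amine or a methoxy group instead of chlorine would behave.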